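Benzyl in place of naphthalen-1-ylmethyl on the piperidine nitrogen

A few compounds are considered here, and "the series" means these few. Any claim that something is new, unique, unknown or untested is made for them only; others in the source may bear on it.

Compound 2 `Fc1ccc(C(OCCC2CCN(Cc3cccc4ccccc34)CC2)c2ccc(F)cc2)cc1` gives 16 nM in an assay on isolated protein for binding affinity to sodium-dependent dopamine transporter (Rattus norvegicus) (a lower number here means a stronger inhibitor, a higher number a weaker inhibitor), the highest of the two numbers recorded so far. Compound 1 `Fc1ccc(C(OCCC2CCN(Cc3ccc(Br)cc3)CC2)c2ccc(F)cc2)cc1` gives 1.1 nM in this assay. Among the compounds with values here, the only measured step is a 15-fold higher number from compound 1 to compound 2 (1.16 log units; beyond the scatter), a large move to a weaker inhibitor. Compound 3 `Fc1ccc(C(OCCC2CCN(Cc3ccccc3)CC2)c2ccc(F)cc2)cc1` is not yet measured; it differs from compound 2 by phenyl in place of naphthalen-1-yl on a saturated chain carbon bound to an amine nitrogen in a ring. Within the data shown here, the step from compound 1 to compound 2 bears on this change only indirectly: it shows that the larger aromatic group on that chain carbon sits far to the weak side, while no measured compound carries the bare phenyl. Removing the second ring is expected to recover part of that loss in this assay, likely falling short of compound 1. Compound 3 is therefore estimated at 3.5 nM, with a range of 1.2 nM to 10 nM, an expected step of a 4.6-fold lower number from compound 2 to compound 3 (0.66 log units; beyond the scatter).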

Compound 3, inhibition constant: 9.9 nM
Compound 3: the middle estimate sits 2.8-fold (0.45 log units) below what was measured; the range from low to high includes it.
By their numbers in this assay, from the lowest: compound 1; then compounds 3 and 2 (each within the scatter of the next).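

In this assay, phenyl in place of naphthalen-1-yl on a saturated chain carbon bound to an amine nitrogen in a ring gives a 1.6-fold lower number from compound 2 to compound 3 (0.21 log units; within the scatter), so the second aromatic ring does not separate these two compounds and they cannot be ordered. The difference lies instead with the bromo group: hydrogen in place of bromo on an aromatic carbon gives a 9.0-fold higher number from compound 1 to compound 3 (0.95 log units; beyond the scatter), which leaves compound 1 as the strongest inhibitor of the three. Nothing measured here accounts for either step.

As far as these compounds go, whether chloro, methoxy or nitrile on that aromatic carbon would match bromo remains open. Also open, from the compounds shown here alone, is whether bromo on the naphthalen-1-yl group would have the same effect as it has on phenyl.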